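A few compounds are considered here, and "the series" means these few. Any claim that something is new, unique, unknown or untested is made for them only; others in the source may bear on it.

Measured so far:
compound 1, `C=CCOC(=O)/C=C(C)/C=C/CC(C)CCCC(C)C`: 6.73
compound 2, `COC(=O)/C=C(C)/C=C/CC(C)CCCC(C)(C)OC`: 5

Both numbers come from a physicochemical assay for lipophilicity; on this read-out higher numbers stand for higher lipophilicity and lower numbers for lower lipophilicity. Compound 2 stands lowest of the two numbers; the nearest value, that of compound 1, lies higher by a gap that is beyond the scatter. Going by the values given here, compound 1 and compound 2 differ in more than one place, so no single step between them is counted; only their two values stand side by side.

Compound 3, `COC(C)(C)CCCC(C)C/C=C/C(C)=C/C(=O)OC1CCCC1`, is not yet measured. It differs from compound 2 in one place: cyclopentyl in place of methyl on an oxygen next to a carbonyl group The change adds a five-membered non-aromatic ring of carbon only and brings no hydrogen-bond donors or acceptors. The expected step of a number 1.70 log units higher from compound 2 to compound 3 (beyond the scatter) is upward and well beyond the scatter. For compound 3 the estimate in this assay is 6.7, with a range from 6.1 to 7.3.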

Compound 3, partition coefficient: 7.01
The estimate for compound 3 lay 0.31 log units below the measured number; low and high end bracket the measured number.
By their numbers in this assay, from the lowest: compound 2; then compounds 1 and 3 (each within the scatter of the next).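

Working from this assay, cyclopentyl in place of methyl on an oxygen next to a carbonyl group gives a number 2.01 log units higher from compound 2 to compound 3 (beyond the scatter) and so provides the first single-place reading in the series. It shows that this position is not silent on this read-out and that a change here alone can produce a large step, which the earlier pair, differing in more than one place, could not show. No measured information bears on the cause of the step's size.

Still open, from the compounds shown here alone, is whether the ring itself or simply the added carbon carries the step, a question that a straight pentyl chain on the same oxygen would help to separate. Going by these compounds, how an amine-bearing group would read at this position also remains open.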